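Replacing chloro with (azetidin-1-yl)methyl on compound 3

The compounds below may be only part of what the source reports. "The series", "measured", "known", "first", "only" and "open" are said of these compounds alone.

Compound 1 `CNc1nccc(N2CC[C@H](NC(=O)Nc3ccc(CN(C)C)c(C(F)(F)F)c3)C2)n1`: 87.8%
Compound 2 `CNc1nccc(N2CC[C@H](NC(=O)Nc3cccc(C#N)c3)C2)n1`: 91.5%
Compound 3 `CNc1nccc(N2CC[C@H](NC(=O)Nc3ccc(Cl)c(C(F)(F)F)c3)C2)n1`: 99.8%

In an ADME assay on a cell-free system (plasma, Mus musculus) for protein binding, compound 3 stands highest of the three at 99.8%, with the lowest unbound fraction, and its gaps to both others lie beyond the scatter. Compound 4 `CNc1nccc(N2CC[C@H](NC(=O)Nc3ccc(CN4CCC4)c(C(F)(F)F)c3)C2)n1` carries (azetidin-1-yl)methyl in place of chloro on an aromatic carbon. Going by the values given here, the one measured step that bears on this is a 61-fold lower unbound fraction from compound 1 to compound 3 (1.79 log units; beyond the scatter), large and beyond the scatter, with chloro in place of (dimethylamino)methyl. Read in reverse, it points towards more free compound in this assay. The expected change is a 60-fold higher unbound fraction from compound 3 to compound 4 (1.78 log units; beyond the scatter), similar in size and opposite in direction. For compound 4 the estimate is 88%, with an expected range of 76% to 95%.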

Compound 4, plasma protein binding: 85.6%
Compound 4: middle estimate off by 1.2-fold (0.08 log units) (unbound fraction), on the low side; low and high end bracket the measured number.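

In this assay, (azetidin-1-yl)methyl in place of chloro gives a 72-fold higher unbound fraction from compound 3 to compound 4 (1.86 log units; beyond the scatter), so the large shift towards free compound at this position is not confined to (dimethylamino)methyl. The two amines barely separate, with azetidin-1-yl in place of dimethylamino giving a 1.2-fold higher unbound fraction from compound 1 to compound 4 (0.07 log units; within the scatter). Nothing available accounts for the shift.

As far as these compounds go, whether this position needs a nitrogen in the group at all stays open, and methoxymethyl would bear on that. So does the reading for larger rings such as (piperidin-1-yl)methyl or (morpholin-4-yl)methyl.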